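A few compounds are considered here, and "the series" means these few. Any claim that something is new, unique, unknown or untested is made for them only; others in the source may bear on it.

In a functional assay on HeLa cells (Homo sapiens) for antiproliferative activity, with a stated time of 24 h (on this read-out higher numbers stand for weaker inhibition and lower numbers for stronger inhibition), compound 1 `NC(=O)c1c(NC(=O)c2ccccc2Cl)sc2c1CCN(C(=S)Nc1ccccc1Br)C2` gives 24600 nM, and compound 2 `Cc1ccccc1C(=O)Nc1sc2c(c1C(N)=O)CCN(C(=S)Nc1ccccc1Cl)C2` gives 35300 nM. Compound 3 `NC(=O)c1c(NC(=O)c2ccccc2C(F)(F)F)sc2c1CCN(C(=S)Nc1ccccc1Br)C2` reaches only a limit in this assay, > 50000 nM, so for it no number but only a bound is known; it stands at the limit of > 50000 nM in this assay, at which 1 of the 3 values shown sits. For the measured compounds named here, the one measured step that touches it, an at least 2.0-fold higher number from compound 1 to compound 3 (0.30 log units; that floor lies within the scatter), is for that reason itself only a floor. The change to compound 4 `Cc1ccccc1C(=O)Nc1sc2c(c1C(N)=O)CCN(C(=S)Nc1ccccc1Br)C2` is methyl in place of trifluoromethyl on an aromatic carbon. Compound 2 also carries a methyl and sits near compound 1. Running the trifluoromethyl back to a methyl is expected to bring the number down in this assay, by roughly an at least 1.6-fold lower number from compound 3 to compound 4 (0.22 log units; that floor lies within the scatter). Compound 4 is therefore expected to give about 30000 nM, within a range of 12000 nM to 80000 nM.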

Compound 4, half-maximal inhibitory concentration: > 50000 nM
Compound 4 was reported as a limit (the forecaster's own chance of this, stated with the estimate: 25%); at least 1.6-fold (0.22 log units) between middle value and limit.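

Methyl in place of trifluoromethyl on an aromatic carbon, ortho to a large group, leaves compound 4 at a limit, as compound 3 is, so the step between them cannot be read. Bromo in place of chloro gives an at least 1.4-fold higher number from compound 2 to compound 4 (0.15 log units; that floor lies within the scatter), and methyl in place of chloro gives an at least 2.0-fold higher number from compound 1 to compound 4 (0.30 log units; that floor lies within the scatter); both are floors only. This end of the series now holds two compounds without a number: the limit of > 50000 nM in this assay, at which 2 of the 4 values shown sit.

Going by these compounds, the true values of compound 3 and compound 4 remain open. So does whether an amine or a carboxylic acid on this carbon would give a number clearly apart from that of compound 1 in this assay.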